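The source may report more compounds than this note shows. Statements on the series, on what has been measured and on what is new or still open speak of the compounds shown alone.

Measured compounds:
- compound 1 `CC(=O)N1N=C(c2ccc3ccccc3c2)OC1c1ccccc1`: 2.11 ug/mL
- compound 2 `CC(=O)N1N=C(c2ccc3ccccc3c2)OC1c1ccccc1[N+](=O)[O-]`: 12.3 ug/mL
- compound 3 `CC(=O)N1N=C(c2ccc3ccccc3c2)OC1c1ccccn1`: 5.26 ug/mL

In a functional assay on HepG2 cells (Homo sapiens) for antiproliferative activity, read by MTT assay, with a stated time of 48 h (on this read-out higher numbers stand for weaker inhibition and lower numbers for stronger inhibition), compound 1 gives 2.11 ug/mL, the lowest number of the three, so it is the strongest inhibitor measured. Replacing a hydrogen on its phenyl with a nitro group gives a 5.8-fold higher number from compound 1 to compound 2 (0.77 log units; beyond the scatter), and swapping the phenyl for a pyridin-2-yl gives a 2.5-fold higher number from compound 1 to compound 3 (0.40 log units; beyond the scatter). Both changes to that ring weakened inhibition, though by different amounts.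

Compound 4 `CC(=O)N1N=C(c2ccc3ccccc3c2)OC1c1ccc(C)cc1` differs from compound 1 as follows: methyl in place of hydrogen on an aromatic carbon, on an aromatic carbon of a six-membered aromatic ring of carbon only. Among the measured compounds shown here, neither measured step involves a methyl, so no step bears directly on this change; the two steps only show that altering this ring has so far raised the number. A small rise or no change beyond the scatter is expected in this assay.

Compound 4 is therefore estimated at 2.6 ug/mL, with a likely range from 1.2 ug/mL to 5.5 ug/mL, an expected step of a 1.2-fold higher number from compound 1 to compound 4 (0.09 log units; within the scatter).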

Compound 4, half-maximal inhibitory concentration: 2.26 ug/mL
Compound 4: the middle estimate sits 1.2-fold (0.06 log units) above what was measured, within the range that was stated.
By their numbers in this assay, from the lowest: compounds 1 and 4 (each within the scatter of the next); then compound 3; then compound 2.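

In this assay the phenyl ring of compound 1 accepts a methyl para to a large group with no change that can be told from the scatter (a 1.1-fold higher number from compound 1 to compound 4 (0.03 log units; within the scatter)). Among the compounds shown here, this is the first change to that ring that leaves the number in place, so the ring does not respond badly to every substitution. The 4-methylphenyl ring also stays ahead of the two other rings, with a 2.3-fold lower number from compound 3 to compound 4 (0.37 log units; beyond the scatter) and a 5.4-fold lower number from compound 2 to compound 4 (0.74 log units; beyond the scatter), but no data shown here explain why the methyl and the nitro group differ.

Going by these compounds, a single methyl says little about larger groups, so a methoxy, an amine or a longer chain such as butyl at this place remains open. Also open, on these data alone, is whether the loss in compound 2 comes from the nitro group itself or from its place on the ring, since it carries 2-nitrophenyl whereas compound 4 carries 4-methylphenyl.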